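The source may report more compounds than this note shows. Statements on the series, on what has been measured and on what is new or still open speak of the compounds shown alone.

Compound 1 `Nc1ncnc2c1ncn2/C=C/C=O` is an adenine-type compound carrying a chain that ends in a formyl group. In a functional assay on HeLa cells (Homo sapiens) for inhibition (a higher number here means a weaker inhibitor, a lower number a stronger inhibitor), compound 1 gives 30000 nM. For the measured compounds named here, the only other compound measured here is compound 2 `Cc1cn(COCCO)c(=O)n(/C=C/C=O)c1=O`, built on a different core but ending in the same chain; in this assay compound 2 gives 20000 nM. The two numbers lie within the scatter of each other, so compound 1 stands with the larger figure of the two but no real separation from compound 2 can be read.

Compound 3 `CCOC(=O)/C=C/n1cnc2c(N)ncnc21` keeps the core of compound 1 and the chain, and differs from compound 1 in one place: ethoxy in place of hydrogen on a carbonyl carbon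

Going by the values given here, no measured pair shows what such a change does in this assay, so the expectation rests on compound 1 alone. Both measured compounds are weak in this assay, and the change does not touch the core, so the expected step is small, if anything toward a weaker number. The step expected is a 1.3-fold higher number from compound 1 to compound 3 (0.12 log units; within the scatter). Compound 3 is estimated at 40000 nM, with a range from 10000 nM to 150000 nM.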

Compound 3, half-maximal inhibitory concentration: 60000 nM
The estimate for compound 3 lay 1.5-fold (0.18 log units) below the measured number, within the range that was stated.
By their numbers in this assay, from the lowest: compounds 2, 1 and 3 (each within the scatter of the next, the first and the last beyond it).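

For the compounds shown here, compound 3 gives the first reading of a change on this carbonyl carbon, whose other neighbour is the double-bonded chain carbon: in this assay, ethoxy in place of hydrogen, which is formyl to ethoxycarbonyl when cut one bond further out, gives a 2.0-fold higher number from compound 1 to compound 3 (0.30 log units; within the scatter) and so no separation that can be read. The formyl hydrogen can therefore give way to ethoxy, with its three heavy atoms and one hydrogen-bond acceptor, on the core of compound 1 without moving the number beyond the scatter, which means that this pair does not show the formyl group to be needed for the reading seen here. Nothing at hand bears on why the two compounds read as they do.

On these data alone, what remains open is whether a carboxylic acid or an amide on the same carbonyl carbon, or a longer chain in place of ethoxy, would give a number clearly separated from that of compound 1. This single pair also leaves open whether formyl to ethoxycarbonyl would give a similar step on the core of compound 2.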